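Swapping a branched phenyl chain for a short amino chain

The compounds below may be only part of what the source reports. "The series", "measured", "known", "first", "only" and "open" are said of these compounds alone.

Compound 1, `Nc1ccc(Nc2c(C(=O)NCc3ccc(F)cc3)nc(Br)c3cccnc23)cc1`: 7000 nM in a functional assay on MDA-MB-435 cells (Homo sapiens) for cytotoxicity, read by MTT assay, with a stated time of 72 h; a higher number here means a weaker inhibitor, a lower number a stronger inhibitor.
Compound 2, `C[C@@H](Nc1c(C(=O)NCc2ccc(F)cc2)nc(Br)c2cccnc12)c1ccccc1`: > 20000 nM in this assay, a limit of the assay rather than a number.

Compound 2 thus stands at the weak end of the scale, with only a limit and no number (the limit of > 20000 nM in this assay, at which 1 of the 2 values shown sits). Compound 3, `NCCNc1c(C(=O)NCc2ccc(F)cc2)nc(Br)c2cccnc12`, differs from compound 2 by 2-aminoethyl in place of 1-phenylethyl on a nitrogen on an aromatic ring. Going by the values given here, the only measured step, an at least 2.8-fold higher number from compound 1 to compound 2 (0.45 log units; beyond the scatter), shows that losing the 4-aminophenyl for 1-phenylethyl weakened inhibition. The 2-aminoethyl brings back one hydrogen-bond donor and one acceptor, so a modest gain is expected, though without a firm number for compound 2 the size is uncertain. Compound 3 is estimated at 15000 nM (range 4000 nM to 60000 nM), an expected step of an at least 1.3-fold lower number from compound 2 to compound 3 (0.12 log units; that floor lies within the scatter).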

Compound 3, half-maximal inhibitory concentration: 12000 nM
For compound 3 the middle estimate is 1.3-fold (0.10 log units) above the measured one; low and high end bracket the measured number.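

Among these compounds, a ring on this nitrogen is not needed for a measurable value: replacing 1-phenylethyl with 2-aminoethyl gives an at least 1.6-fold lower number from compound 2 to compound 3 (0.22 log units; that floor lies within the scatter). From the compounds shown here alone, compound 2 has only a limit, so the true size of that step stays unknown: the limit of > 20000 nM in this assay, at which 1 of the 3 values shown sits. Replacing 4-aminophenyl with the much smaller 2-aminoethyl gives a 1.7-fold higher number from compound 1 to compound 3 (0.23 log units; within the scatter), so these two groups cannot be told apart here.

Still open, going by these compounds, is whether the amine itself matters, and whether a longer chain such as 3-aminopropyl, or a carboxylic acid in place of the amine, would shift the number beyond the scatter.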